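The compounds below may be only part of what the source reports. "The series", "measured", "known", "first", "only" and "open" are said of these compounds alone.

Among the three compounds measured in an assay on isolated protein for inhibition of Amine oxidase [flavin-containing] B (Homo sapiens), read by fluorescence and Amplex Red, with stated times of 15 min and 20 min (on this read-out lower numbers stand for stronger inhibition and higher numbers for weaker inhibition), compound 2 `C#CCN(CCCOc1ccc2ccc(=O)oc2c1)Cc1ccc(OC)cc1` gives the highest number, 6080 nM. Within the data shown here, compound 1 `C#CCN(CCCCOc1ccc2ccc(=O)oc2c1)Cc1cccc(OC)c1` gives 2340 nM and compound 3 `C#CCN(CCCCOc1ccc2ccc(=O)oc2c1)Cc1ccc(F)c(F)c1` gives 2370 nM; the only step between compounds differing in one place, a 1.0-fold higher number from compound 1 to compound 3 (0.01 log units; within the scatter), stays within the scatter. Compound 4 `C#CCN(CCCOc1ccc2ccc(=O)oc2c1)Cc1cccc(OC)c1` is an unmeasured rearrangement of compound 2: 3-methoxyphenyl in place of 4-methoxyphenyl on a saturated chain carbon bound to an amine nitrogen. Among the measured compounds shown here, no measured step isolates this change. Compound 1 and compound 2 differ in the chain length as well as in the methoxyphenyl, so their values only hint that the 3-methoxyphenyl may come with a lower number. Compound 4 is therefore expected to sit somewhat below compound 2, with a 1.7-fold lower number from compound 2 to compound 4 (0.24 log units; within the scatter), at an estimated 3500 nM in this assay, within a range of 1500 nM to 8000 nM.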

Compound 4, half-maximal inhibitory concentration: 4590 nM
Compound 4: middle estimate off by 1.3-fold (0.12 log units), on the low side, and the stated range covers the measured number.
By their numbers in this assay, from the lowest: compounds 1, 3, 4 and 2 (each within the scatter of the next, the first and the last beyond it).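

The earlier compounds shown here offered this change only alongside a difference in chain length, whereas here it stands alone. In this assay the swap of 4-methoxybenzyl to 3-methoxybenzyl gives a step (a 1.3-fold lower number from compound 2 to compound 4 (0.12 log units; within the scatter)) that stays within the scatter, so these two compounds show no separation from moving the methoxy group. Nothing available explains this result.

On these data alone, whether the change reads the same on the longer chain of compound 1 remains open. So does the outcome of replacing the methoxy group with a trifluoromethyl group or a nitrile.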